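The source may report more compounds than this note shows. Statements on the series, on what has been measured and on what is new or still open speak of the compounds shown alone.

Measured compounds:
Compound 1 `COc1ccc(/C=N/NC(=O)Nc2cc3c(Nc4ccc(F)c(Cl)c4)ncnc3cc2O[C@H]2CCOC2)c(OC)c1OC` gives 33800 nM in a functional assay on MCF7 cells (Homo sapiens) for cytotoxicity, read by MTT assay, with a stated time of 72 h; on this read-out higher numbers stand for weaker inhibition and lower numbers for stronger inhibition.
Compound 2 `O=C(N/N=C/c1ccc(O)c(Br)c1)Nc1cc2c(Nc3ccc(F)c(Cl)c3)ncnc2cc1O[C@H]1CCOC1` gives 2690 nM in this assay.

Compound 2 has the lower of these two numbers, set apart from compound 1 by a 13-fold lower number from compound 1 to compound 2 (1.10 log units; beyond the scatter). Compound 3 `COc1cc2ncnc(Nc3ccc(F)c(Cl)c3)c2cc1NC(=O)N/N=C/c1ccc(O)c(Br)c1` differs from compound 2 by methyl in place of oxolan-3-yl on an oxygen on an aromatic ring. Within the data shown here, the single measured step changes a different part of the molecule, so no measured step bears on this change, and nothing in the data shows what exchanging these two groups does. For compound 3 the expected change is a 1.1-fold higher number from compound 2 to compound 3 (0.05 log units; within the scatter), within the scatter. The estimate for compound 3 is 3000 nM, ranging from 1000 nM to 9000 nM.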

Compound 3, half-maximal inhibitory concentration: "not active" (no number reported)
The entry for compound 3 holds no number, and the estimate cannot be compared.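

Compound 3 is recorded as "not active" with no number, so no step from compound 2 can be read, and nothing available here explains that entry. Going by these compounds, how methoxy in place of (oxolan-3-yl)oxy shifts the number in this assay stays open.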